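The source may hold more compounds than are shown below. What is called first, only, known or untested is meant among the compounds shown, and "the series" means these compounds.

Of the compounds shown here, two built on the same core have been tested in a functional assay on the whole organism (strain albino) for inhibition, with Rattus norvegicus as the target, read by paw edema, with stated times of 1 h and 2 h, at a dose of 20 mmol/kg by the intraperitoneal route; a higher number here means more inhibition at the dose given (going by the name of the read-out), a lower number less inhibition. Compound 1 `N#CC1=C(NCC(=O)N2CCCC2)N(c2ccccc2)C(=O)N2CCCCC(N3CCCC3)C12` gives 49.8% there, and compound 2 `N#Cc1c2n(c(=O)n(-c3ccccc3)c1=N)CCCCC2N1CCCC1` gives 88.7%. Of these two numbers compound 1 stands at the lower end, and its nearest neighbour, compound 2, sits higher by a gap that lies beyond the usual scatter of repeated runs. Compound 3 `N#CC1=C(/N=C/Nc2ccccc2)N(c2ccccc2)C(=O)N2CCCCC(N3CCCC3)C12` has not yet been measured. It differs from compound 1 in a single place: a group of 9 heavy atoms (7 carbon, 2 nitrogen; one six-membered aromatic ring of carbon only) in place of a group of 9 heavy atoms (6 carbon, 2 nitrogen, 1 oxygen; one five-membered non-aromatic ring with 1 hetero atom), on a double-bonded ring carbon. Among the measured compounds shown here, no measured pair shows this particular change, so the size of its effect is unknown from the data at hand. With compound 2 at 88.7% and compound 1 at 49.8%, the range seen so far is wide, and the step from compound 1 to compound 3 is expected to be a number 10.2 percentage points higher from compound 1 to compound 3 (beyond the scatter), a moderate rise. Compound 3 is therefore estimated to give 60%, with a likely range from 40% to 80%.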

Compound 3, a percentage reported as inhibition, in the whole organism at one dose (the size of the read-out at that dose, not a potency): 47.5%
The estimate for compound 3 lay 12.5 percentage points above the measured number; the range from low to high includes it.
By their numbers in this assay, from the lowest: compounds 3 and 1 (each within the scatter of the next); then compound 2.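

In this assay, exchanging the (((pyrrolidin-1-yl)carbonyl)methyl)amino group on the double-bonded ring carbon for the group with a six-membered aromatic ring of carbon only gives a number 2.3 percentage points lower from compound 1 to compound 3 (within the scatter). This position therefore carries either a five-membered non-aromatic ring with 1 hetero atom or a six-membered aromatic ring of carbon only, with or without the oxygen of the leaving group, and this read-out at one dose does not tell the two apart. Nothing at hand bears on why the two groups read alike.

From the compounds shown here alone, it remains open whether a group of another kind at this carbon, such as a carboxylic acid or a simple unsubstituted amine, would move the number beyond the scatter. Going by these compounds, a longer chain between the amino nitrogen and the carbonyl also remains untested by these compounds.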